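Isobutoxy to propoxy: compound 3 to compound 4

The compounds below may be only part of what the source reports. "The series", "measured", "known", "first", "only" and "open" are said of these compounds alone.

Measured in a functional assay on HCT-8 cells (Homo sapiens) for antiproliferative activity, read by sulforhodamine B assay, with a stated time of 3 days (a higher number here means that more compound is needed for the effect, a lower number that less compound is needed), so far
Compound 1 `CCCC1=C(OC)C(CCC)(CCC)C(=O)/C(=C(O)\C=C\c2ccc(I)cc2)C1=O` gives 1.1 uM
Compound 2 `COC1=C(CC(C)C)C(=O)/C(=C(O)/C=C/c2ccccc2)C(=O)C1(CC(C)C)CC(C)C` gives 7.5 uM
Compound 3 `CCCC1=C(OCC(C)C)C(CCC)(CCC)C(=O)/C(=C(O)\C=C\c2ccccc2)C1=O` gives 8 uM

Compound 2 and compound 3 lie within the scatter of each other, while compound 1 gives a lower number than compound 3, beyond the scatter. Compound 4 `CCCOC1=C(CCC)C(=O)/C(=C(O)/C=C/c2ccccc2)C(=O)C1(CCC)CCC` differs from compound 3 by hydrogen in place of methyl on a saturated chain carbon bound to two saturated chain carbons in the change of isobutoxy to propoxy, with hydrogen in place of methyl. Within the data shown here, no measured pair isolates this change. Compound 2 at 7.5 uM and compound 3 at 8 uM carry different chains yet stay within the scatter, so a step within the scatter, without a firm direction, is expected in this assay for this change. The expected 1.1-fold lower number from compound 3 to compound 4 (0.06 log units; within the scatter) is small. For compound 4 the estimated value is 7 uM with an expected range from 3 uM to 16 uM in this series.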

Compound 4, concentration for half-maximal effect: 2.6 uM
Compound 4: middle estimate off by 2.7-fold (0.43 log units), on the high side; measured number outside the range, below it.
By their numbers in this assay, from the lowest: compound 1; then compound 4; then compounds 2 and 3 (each within the scatter of the next).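

In this assay, losing the methyl that turns isobutoxy into propoxy gives a 3.1-fold lower number from compound 3 to compound 4 (0.49 log units; beyond the scatter) and so shows that this ether chain is sensitive to a single carbon. Among these compounds, this is the first step that isolates one change, and hydrogen in place of methyl on this saturated chain carbon moves the number beyond the scatter. Nothing shown here explains the step.

Still open, going by these compounds, is whether butoxy or a propoxy chain ending in an amine would keep the lower number. The compounds shown also leave open whether isopropyl to ethyl elsewhere on the core has a similar effect.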